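The source may hold more compounds than are shown below. What is called first, only, known or untested is meant among the compounds shown, and "the series" means these compounds.

Measured compounds and their solubility values:

Compound 1, `COc1ccc2[nH]c(C(=O)N3CC(=O)N(Cc4ccccc4)[C@@H](CCc4ccccc4)C3)cc2c1`, gives 4400 nM in a physicochemical assay for solubility, read by spectrophotometry, in phosphate buffer, with a stated time of 2 h, at pH 7.4; a higher number here means a more soluble compound, a lower number a less soluble compound.
Compound 2, `Cc1ccc2[nH]c(C(=O)N3CC(=O)N(Cc4ccccc4)[C@@H](CN4CCC5(CCC5)CC4)C3)cc2c1`, gives 12300 nM in this assay.
Compound 3, `COc1ccc2[nH]c(C(=O)N3CC(=O)N(Cc4ccoc4)[C@@H](Cc4ccccc4)C3)cc2c1`, gives 63600 nM in this assay.

Among these three, compound 1 stands lowest. Its nearest neighbour is compound 2, whose number is higher by a margin beyond the usual scatter, and the furthest is compound 3, higher still and also beyond the scatter. For the measured compounds named here, none of the three measured compounds differ from one another in only one place, so no single-point step is available to lean on.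

Compound 4, `COc1ccc2[nH]c(C(=O)N3CC(=O)N(Cc4ccccc4)[C@@H](CN4CC5CC5C4)C3)cc2c1`, is the one-place neighbour of compound 1. The change is a group of 6 heavy atoms (5 carbon, 1 nitrogen; one three-membered non-aromatic ring of carbon only, one five-membered non-aromatic ring with 1 hetero atom) in place of a group of 7 heavy atoms (7 carbon; one six-membered aromatic ring of carbon only), on a saturated chain carbon bound to a saturated ring carbon.

Going by the values given here, the one measured compound that also carries a saturated ring bearing a nitrogen on that chain is compound 2, with 12300 nM, the second-highest value here. On that basis the step in this assay from compound 1 to compound 4 is expected to go upward and to exceed the scatter, at about a 3.4-fold higher number from compound 1 to compound 4 (0.53 log units; beyond the scatter). Compound 4 is therefore estimated at 15000 nM, with a range from 5000 nM to 45000 nM.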

Compound 4, solubility: 17500 nM
Estimate against measurement, compound 4: 1.2-fold (0.07 log units) below; measured number inside the range.
By their numbers in this assay, from the lowest: compound 1; then compounds 2 and 4 (each within the scatter of the next); then compound 3.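

In this assay, the replacement of benzyl on a saturated chain carbon bound to a saturated ring carbon now has a size of its own: a 4.0-fold higher number from compound 1 to compound 4 (0.60 log units; beyond the scatter). The earlier compounds shown here could not show this, since they differed from one another in more than one place, whereas here the rest of compound 1 stays the same and this one position alone is enough to move the number beyond the scatter. The entering group has a ring nitrogen and one hydrogen-bond acceptor, and it has no aromatic ring, but nothing measured here ties the step to any of these features.

The compounds shown leave open whether the step follows the nitrogen or the loss of the six-membered aromatic ring, a question that a cyclohexyl group, with no nitrogen, or an open-chain dimethylamino group at the same place could help to separate. They also leave open whether the same replacement would give a similar step with the other groups on the shared core changed, such as a carboxylic acid on the benzyl group attached to the ring nitrogen.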